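This account rests on a few compounds, and the source may have more. Where it says the series, first, only, none or still open, it means among the compounds named here.

Compound 1: `CCOC(=O)NC(=O)NC1=CS(=O)(=O)O[C@@]12[C@@H](CO[Si](C)(C)C(C)(C)C)O[C@@H](n1cc(C)c(=O)n(C)c1=O)[C@@H]2O[Si](C)(C)C(C)(C)C`, 3000 nM
Compound 2: `CCOC(=O)CNC(=O)NC1=CS(=O)(=O)O[C@@]12[C@@H](CO[Si](C)(C)C(C)(C)C)O[C@@H](n1cc(C)c(=O)n(C)c1=O)[C@@H]2O[Si](C)(C)C(C)(C)C`, 5020 nM
Compound 3: `Cc1cn([C@@H]2O[C@H](CO[Si](C)(C)C(C)(C)C)[C@@]3(OS(=O)(=O)C=C3NCC(=O)OCc3ccccc3)[C@H]2O[Si](C)(C)C(C)(C)C)c(=O)n(C)c1=O`, 250000 nM

All three were measured in a functional assay on CCRF-CEM cells (Homo sapiens); on this read-out lower numbers stand for higher toxicity in this test and higher numbers for lower toxicity in this test. Compound 3 stands at the highest number of the three, that is, it is the least toxic in this assay: the two urea-bearing compounds lie far below it, with an 83-fold higher number from compound 1 to compound 3 (1.92 log units; beyond the scatter) and a 50-fold higher number from compound 2 to compound 3 (1.70 log units; beyond the scatter). Between the two ureas themselves the difference is small, a 1.7-fold higher number from compound 1 to compound 2 (0.22 log units; within the scatter).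

Compound 4, `COC(=O)CCNC1=CS(=O)(=O)O[C@@]12[C@@H](CO[Si](C)(C)C(C)(C)C)O[C@@H](n1cc(C)c(=O)n(C)c1=O)[C@@H]2O[Si](C)(C)C(C)(C)C`, has not yet been measured in this assay. Against compound 3 its difference is (methoxycarbonyl)methyl in place of benzyloxycarbonyl on a saturated chain carbon bound to an amine nitrogen Cut one bond further out, the same difference reads (benzyloxycarbonyl)methyl to 2-(methoxycarbonyl)ethyl on the amine nitrogen.

Within the data shown here, none of the measured steps alters the ester chain on an amine nitrogen. The two large steps to compound 3 concern the urea against the amine, a feature compound 4 shares with compound 3 and not with compound 1 or compound 2. Among the measured compounds shown here, the only step that varies an ester portion is the one between the ureas, and it stayed within the scatter. Compound 4 is therefore expected to remain close to compound 3, with a 1.3-fold lower number from compound 3 to compound 4 (0.10 log units; within the scatter) as the expected step. The estimate for compound 4 in this assay is 200000 nM, within a range from 50000 nM to 600000 nM.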

Compound 4, half-maximal cytotoxic concentration: > 250000 nM
Compound 4: no number, only a limit (the forecaster's own chance of this, stated with the estimate: 25%); middle value at least 1.2-fold (0.09 log units) away from the limit.
By their numbers in this assay, from the lowest: compounds 1 and 2 (each within the scatter of the next); then compound 3.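

In this assay compound 4 gives only a limit of the assay and not a number: the limit of > 250000 nM in this assay, at which 1 of the 4 values shown sits.

Its 2-(methoxycarbonyl)ethyl chain on the amine nitrogen nevertheless places it with compound 3 and apart from the two ureas, with an at least 49-fold higher number from compound 2 to compound 4 (1.69 log units; beyond the scatter) and an at least 83-fold higher number from compound 1 to compound 4 (1.92 log units; beyond the scatter), so the large gap to the ureas now holds for a second ester chain on that nitrogen and is not tied to the benzyloxycarbonyl group of compound 3. For the change from benzyloxycarbonyl to (methoxycarbonyl)methyl itself the data give only a number no lower from compound 3 to compound 4 (the limit leaves the size open) and so the two ester chains on the amine nitrogen cannot be ranked against each other.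

The compounds shown leave open whether a carboxylic acid in place of the methyl ester, or a longer chain on the amine nitrogen, would bring the number down towards those of the ureas. Nor do they tell whether an unsubstituted amino group on the shared core would give a readable number in this assay.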